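The compounds below may be only part of what the source reports. "The series", "measured", "known", "first", "only" and "open" are said of these compounds alone.

Measured compounds:
Compound 1 `O=C(CSC(=S)N[C@H]1CCOC1=O)Nc1ccc(Br)cc1` gives 28300 nM in a functional assay on SMMC-7721 cells (Homo sapiens) for cytotoxicity, read by MTT assay, with a stated time of 72 h; a lower number here means a stronger inhibitor, a higher number a weaker inhibitor.
Compound 2 `Cc1cccc(NC(=O)CSC(=S)N[C@H]2CCOC2=O)c1` reaches only the limit of > 128000 nM in this assay.
Compound 3 `O=C(CSC(=S)N[C@H]1CCOC1=O)Nc1cccc(Cl)c1` likewise reaches only the limit of > 128000 nM in this assay.

Among the compounds with values here, compound 1 therefore stands as the only compound with a true number; the other two values are the limit of the assay (the limit of > 128000 nM in this assay, at which 2 of the 3 values shown sit). Compound 4 `O=C(CSC(=S)N[C@H]1CCOC1=O)Nc1ccc(C(=O)/C=C/c2ccccc2)cc1` differs from compound 1 in one place: (2-phenylethenyl)carbonyl in place of bromo on an aromatic carbon. Within the data shown here, two measured steps bear on this, though only loosely, since both swap the whole 4-bromophenyl rather than replace its bromo: an at least 4.5-fold higher number from compound 1 to compound 2 (0.65 log units; beyond the scatter) and an at least 4.5-fold higher number from compound 1 to compound 3 (0.65 log units; beyond the scatter). Each shows that changing what sits on the aryl amide can push the number upward beyond the scatter, but neither step keeps a group on the aromatic carbon para to a large group, as compound 4 does. The step to compound 4 is thus not mapped by the measured pairs. The expectation for compound 4 is an inhibitory concentration near 15000 nM, with a plausible range from 3000 nM to 80000 nM. That estimate means a step of a 1.9-fold lower number from compound 1 to compound 4 (0.28 log units; within the scatter), expected to stay within or only modestly beyond the scatter.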

Compound 4, half-maximal inhibitory concentration: > 128000 nM
Compound 4: only a limit was reported; the forecaster's own chance of this, stated with the estimate: 15%; middle value at least 8.5-fold (0.93 log units) from the limit.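

Replacing only the bromo with (2-phenylethenyl)carbonyl, on the same aromatic carbon para to a large group, gives an at least 4.5-fold higher number from compound 1 to compound 4 (0.65 log units; beyond the scatter) in this assay. Within the data shown here, the earlier steps swapped the whole 4-bromophenyl, whereas this one leaves the rest of compound 1 in place, so it is the first direct sign that the group on this carbon alone can move the number beyond the scatter. The value of compound 4 is a limit and not a true number, so the full size of this step stays unknown, and the steps among compound 2, compound 3 and compound 4 cannot be read, with this limit shared by all three: the limit of > 128000 nM in this assay, at which 3 of the 4 values shown sit.

The compounds shown leave open whether a small group on this carbon, such as fluoro, or an amine or a carboxylic acid, would keep, lower or raise the number of compound 1. They also cannot say which part of the (2-phenylethenyl)carbonyl goes with the higher number, whether its carbonyl, its double bond or its ring, or whether a plain acetyl would behave the same way.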